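Chloro on the phenoxy group of compound 1

A few compounds are considered here, and "the series" means these few. Any claim that something is new, unique, unknown or untested is made for them only; others in the source may bear on it.

Among the measured compounds shown here, in a functional assay on HCT-116 cells (Homo sapiens) for antiproliferative activity, read by MTT assay, with a stated time of 72 h (on this read-out higher numbers stand for weaker inhibition and lower numbers for stronger inhibition), only two compounds have numbers so far. Compound 1 `NC1=NC2(CCOCC2)N(OCCCOc2ccccc2)C(N)=N1` reads 6010 nM and stands highest of the two. Compound 2 `NC1=NC2(CCSCC2)N(OCCCOc2cccc(Cl)c2)C(N)=N1` reads 1 nM on the same read-out, a gap from compound 1 that lies well beyond the scatter.

Compound 3 `NC1=NC2(CCOCC2)N(OCCCOc2ccccc2Cl)C(N)=N1` keeps the core of compound 1 and turns phenoxy into 2-chlorophenoxy, with chloro in place of hydrogen on an aromatic carbon, ortho to a large group (chloro in place of hydrogen on an aromatic carbon). For the measured compounds named here, no measured pair isolates a single change, so the size of this step has no direct precedent. The low number of compound 2 (1 nM) shows only that the series can reach strong inhibition. A moderate step toward stronger inhibition in this assay is expected, beyond the scatter but far short of the whole gap. The estimated size is a 7.5-fold lower number from compound 1 to compound 3 (0.88 log units; beyond the scatter) (an uncertain expectation). Compound 3 is estimated at 800 nM (expected range 60 nM to 6000 nM).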

Compound 3, half-maximal inhibitory concentration: 70 nM
For compound 3 the middle estimate is 11-fold (1.06 log units) above the measured one, and the stated range covers the measured number.
By their numbers in this assay, from the lowest: compound 2; then compound 3; then compound 1.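

Among the compounds shown here, this is the first step that isolates a single place: in this assay, chloro in place of hydrogen on an aromatic carbon, ortho to a large group, gives an 86-fold lower number from compound 1 to compound 3 (1.93 log units; beyond the scatter) with the rest of compound 1 unchanged. The change from phenoxy to 2-chlorophenoxy adds only one heavy atom, with no hydrogen-bond donor or acceptor and no net charge, yet that is enough for a large step on this read-out, so this aromatic carbon is not indifferent to substitution. Nothing measured here bears on what lies behind the size of this step.

Still open, from the compounds shown here alone, is whether fluoro, bromo, methyl or methoxy on the same aromatic carbon would give a step of similar size, and whether chloro on another carbon of that ring would match it. For the compounds shown here, also open is whether the same step holds on the core of compound 2, or with a longer chain in place of the one linking the phenoxy group to the core.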